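This account rests on a few compounds, and the source may have more. Where it says the series, first, only, none or still open, it means among the compounds named here.

Compounds 1 and 2 share one core; compound 1 is `CN(C)CCCNc1nc(-c2ccc(NC(=O)Nc3ccc(Cl)cc3)cc2)nc2c(Cl)c(Cl)sc12` and compound 2 is `CN(C)CCCNc1nc(-c2ccc(NC(=O)Nc3ccccc3Cl)cc2)nc2c(Cl)c(Cl)sc12`. In a functional assay on MKN-45 cells (Homo sapiens) for cytotoxicity, read by MTT assay, with a stated time of 72 h (a lower number here means a stronger inhibitor, a higher number a weaker inhibitor), compound 1 gives 1530 nM, and compound 2 gives 1330 nM. The only difference between them is 2-chlorophenyl in place of 4-chlorophenyl on an amide-type nitrogen. The step it made was a 1.2-fold lower number from compound 1 to compound 2 (0.06 log units; within the scatter), so the two numbers cannot be told apart.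

Compound 3, `CCN(CC)CCNc1nc(-c2ccc(NC(=O)Nc3ccc(Cl)cc3)cc2)nc2ccsc12`, carries a different core; how the two cores differ is not broken down here. In this assay compound 3 gives 370 nM, which stands as the lowest of the three measured numbers, with compound 2 and compound 1 both well beyond the scatter above it.

Compound 4, `CCN(CC)CCNc1nc(-c2ccc(NC(=O)Nc3ccccc3Cl)cc2)nc2ccsc12`, has not yet been measured. It is built from compound 3 by the same change that turns compound 1 into compound 2: 2-chlorophenyl in place of 4-chlorophenyl on an amide-type nitrogen. The place of the change is the same in both pairs, an amide-type nitrogen whose other neighbour is a carbonyl carbon.

Because the same change gave a 1.2-fold lower number from compound 1 to compound 2 (0.06 log units; within the scatter), the expected step from compound 3 to compound 4 is small, a 1.2-fold lower number from compound 3 to compound 4 (0.06 log units; within the scatter), resting on that single earlier pair and on the reading of compound 3 at 370 nM. For compound 4 in this assay the estimate is 320 nM, with a plausible range from 150 nM to 700 nM, wide enough to cover the ordinary scatter of such a measurement.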

Compound 4, half-maximal inhibitory concentration: 750 nM
Beside the measured number, compound 4's estimate is 2.3-fold (0.37 log units) below it; the measured number lies above the stated range.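

In this assay, putting 2-chlorophenyl in place of 4-chlorophenyl on the amide-type nitrogen gave a 2.0-fold higher number from compound 3 to compound 4 (0.31 log units; beyond the scatter), a modest step that can be read as real, while on the other core the same change gave a 1.2-fold lower number from compound 1 to compound 2 (0.06 log units; within the scatter), too small to read. Placed side by side, these two steps cannot be told apart, even though only one of them stands clear of the scatter on its own: the same change on two cores in this assay, a 1.2-fold lower number (0.06 log units; within the scatter) from compound 1 to compound 2 and a 2.0-fold higher number (0.31 log units; beyond the scatter) from compound 3 to compound 4, 2.3-fold (0.37 log units) apart, within the scatter of two such steps. So the data give no sign that this change behaves differently on the two cores, but they do not prove that it carries over unchanged, since each core offers only one pair and the true steps could still differ by an amount that these numbers cannot resolve.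

The compounds shown leave open how a plain phenyl, a fluorophenyl or a methoxyphenyl on that amide-type nitrogen would compare with the two chlorophenyl groups. They also leave open whether the step would hold on either core with a morpholine in place of the amine at the end of the side chain.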